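The source may hold more compounds than are shown below. What is called first, only, known or untested is meant among the compounds shown, and "the series" means these compounds.

Compound 1 `CC1CCC(=O)N1CC#CCn1ccnc1` and compound 2 `CC1CCC(=O)N1CC#CCN(C)C` share one core and differ in a single place: dimethylamino in place of 1H-imidazol-1-yl on a saturated chain carbon bound to a triple-bonded carbon. In a functional assay on the whole organism for antagonist activity, with Mus musculus as the target (a higher number here means that more compound is needed for the effect, a lower number that less compound is needed), compound 1 gives 20.9 mg/kg. For compound 2 this assay reports only a limit, > 100 mg/kg. That change therefore brings an at least 4.7-fold higher number from compound 1 to compound 2 (0.67 log units; beyond the scatter). Compound 3 `COC(=O)N(C)C(C)C#CCn1ccnc1` is built on another core; how the two cores differ is not broken down here. For compound 3 this assay again reports only a limit, > 100 mg/kg. Compound 4 `COC(=O)N(C)C(C)C#CCN(C)C` is not yet measured and stands to compound 3 as compound 2 stands to compound 1, the same change: dimethylamino in place of 1H-imidazol-1-yl on a saturated chain carbon bound to a triple-bonded carbon. Because the earlier pair gave an at least 4.7-fold higher number from compound 1 to compound 2 (0.67 log units; beyond the scatter), and because the limit of > 100 mg/kg in this assay, at which 2 of the 3 values shown sit, already holds compound 3, compound 4 is expected to show a step that the limit leaves unreadable from compound 3 to compound 4 and to stay beyond that limit. The estimate for compound 4 is 400 mg/kg, expected between 120 mg/kg and 1500 mg/kg.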

Compound 4, dose for half-maximal effect: > 100 mg/kg
Compound 4 was reported as a limit (the forecaster's own chance of this, stated with the estimate: 95%); the middle value does not contradict the limit.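

In this assay compound 3 and compound 4 both sit at a limit, so no step between them can be read: the limit of > 100 mg/kg in this assay, at which 3 of the 4 values shown sit.

The compounds shown leave open whether dimethylamino in place of 1H-imidazol-1-yl changes anything on the core of compound 3.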